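The source may hold more compounds than are shown below. What is called first, only, known or untested is meant among the compounds shown, and "the series" means these compounds.

Measured in a physicochemical assay for lipophilicity, using the shake flask method, in phosphate buffer, measured as octanol-water partition, with a stated time of 30 min, at pH 7.4; on this read-out lower numbers stand for lower lipophilicity and higher numbers for higher lipophilicity:

- Compound 1 `O=C(Nc1ccccc1)c1cnc(NCc2c(F)ccc3c2CCO3)n2cnnc12`: 4.1
- Compound 2 `Cc1ncccc1-c1cnc(NCc2c(F)ccc3c2CCO3)c2nn(CC#N)c(=O)n12`: 2.2
- Compound 3 `Fc1ccc2c(c1CNc1ncc(Oc3ccccc3)c3nncn13)CCO2`: 3.5

Compound 2, at 2.2, has the lowest number of the three. Compound 3 stands at 3.5, and compound 1 stands at 4.1. The gap from compound 2 to each of these two lies beyond the scatter.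

The account now turns to compound 4 `Cc1ncccc1-c1cnc(NCc2c(F)ccc3c2CCO3)c2n[nH]c(=O)n12`, which has not yet been measured in this assay. It differs from compound 2 in one place: hydrogen in place of cyanomethyl on an aromatic nitrogen. In words, this is hydrogen in place of cyanomethyl on an aromatic nitrogen.

Going by the values given here, only one measured step is available for comparison, a number 0.60 log units lower from compound 1 to compound 3 (beyond the scatter). It is modest and beyond the scatter, but it involves phenoxy in place of phenylcarbamoyl on an aromatic carbon, a different change at a different place. It therefore offers a guide to size and says nothing firm about direction. Among the compounds with values here, no measured pair shows the loss of cyanomethyl.

A modest fall of similar size is tentatively expected, although the estimated range also allows for no change. The estimated step is a number 0.50 log units lower from compound 2 to compound 4 (beyond the scatter). For compound 4, the estimated value is 1.7, with an expected range from 1.1 to 2.3.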

Compound 4, distribution coefficient: 2.5
For compound 4 the middle estimate is 0.80 log units below the measured one, and the stated range ends below it.
By their numbers in this assay, from the lowest: compounds 2 and 4 (each within the scatter of the next); then compound 3; then compound 1.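

Replacing cyanomethyl with hydrogen on the aromatic nitrogen of the five-membered ring gives a number 0.30 log units higher from compound 2 to compound 4 (within the scatter) in this assay, so the two compounds cannot be told apart on this read-out. Going by these compounds alone, this is the first view of this position, since the only earlier step concerned an aromatic carbon and lay beyond the scatter: here, 3 heavy atoms, a triple bond and a hydrogen-bond acceptor leave together without a step beyond the scatter. Nothing available accounts for this result, which stands as a measured observation on a single pair of compounds.

The compounds shown leave open how other groups on this nitrogen would read in this assay, such as a methyl group, a longer alkyl chain, an amine or a carboxylic acid. Within the data shown here, they also leave open whether the same exchange of cyanomethyl for hydrogen would stay within the scatter if other parts of the molecule were different, as this single pair is the only one that carries the change.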